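Shortening the Amine Chain from Butyl to Ethyl

The source may report more compounds than this note shows. Statements on the series, on what has been measured and on what is new or still open speak of the compounds shown alone.

Of the compounds shown here, three built on one shared core have been measured in an assay on isolated protein for inhibition of Amine oxidase [flavin-containing] A (Homo sapiens), read by fluorescence and Amplex Red, with a stated time of 30 min, tested at 1 mM; a lower number here means a weaker effect, a higher number a stronger effect of the compound at the concentration tested. Compound 1 `CCCCNc1nnc(SCC(=O)N(Cc2cccc([N+](=O)[O-])c2)c2ccc(F)cc2)s1` gives 90.5%. Compound 2 `C=CCNc1nnc(SCC(=O)N(Cc2cccc([N+](=O)[O-])c2)c2ccc(F)cc2)s1` gives 92%, and compound 3 `CC(C)Nc1nnc(SCC(=O)N(Cc2cccc([N+](=O)[O-])c2)c2ccc(F)cc2)s1` gives 92.5%. Compound 1 holds the lowest of the three numbers, yet the step of a number 1.5 percentage points higher from compound 1 to compound 2 (within the scatter) and the step of a number 2 percentage points higher from compound 1 to compound 3 (within the scatter) both sit within the scatter, so the three compounds cannot be told apart on these numbers. Compound 4 `CCNc1nnc(SCC(=O)N(Cc2cccc([N+](=O)[O-])c2)c2ccc(F)cc2)s1` has not yet been measured. It differs from compound 1 as follows: hydrogen in place of ethyl on a saturated chain carbon, two bonds along the chain from a nitrogen on an aromatic ring. The measured steps that bear on this change are the ones altering the same chain, namely a number 1.5 percentage points higher from compound 1 to compound 2 (within the scatter), a number 2 percentage points higher from compound 1 to compound 3 (within the scatter) and a number 0.5 percentage points higher from compound 2 to compound 3 (within the scatter); none of them moved the number beyond the scatter. Going from butyl to ethyl is therefore expected to give a number 0.5 percentage points lower from compound 1 to compound 4 (within the scatter), a step no larger than the scatter. For compound 4 the expected value is 90%, with a range from 80% to 96%.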

Compound 4, a percentage reported as inhibition, at one concentration (the size of the read-out at that concentration, not a potency): 93.6%
Beside the measured number, compound 4's estimate is 3.6 percentage points below it; the range from low to high includes it.
By their numbers in this assay, from the lowest: compounds 1, 2, 3 and 4 (each within the scatter of the next).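

In this assay, shortening butyl to ethyl gives a number 3.1 percentage points higher from compound 1 to compound 4 (within the scatter), so removing those two carbons does not separate compound 4 from compound 1. The comparisons with the branched and unsaturated chains, a number 1.1 percentage points higher from compound 3 to compound 4 (within the scatter) and a number 1.6 percentage points higher from compound 2 to compound 4 (within the scatter), also stay within the scatter, so ethyl, butyl, allyl and isopropyl cannot be told apart here, and all four compounds sit close to complete inhibition. No measurement available here offers an explanation for this flat result.

Still open, from the compounds shown here alone, is whether methylamino, a plain amino group or a chain ending in a carboxylic acid, in place of butylamino, would move the number beyond the scatter. Also open, going by these compounds, is whether these four compounds would separate into stronger and weaker effects at a lower test concentration.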